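Swapping the Chalcone Orientation on a Weak Antiproliferative Scaffold

A few compounds are considered here, and "the series" means these few. Any claim that something is new, unique, unknown or untested is made for them only; others in the source may bear on it.

Of the compounds shown here, two built on a shared fused core have been measured in an ADME assay on HEK293 cells (Homo sapiens) for antiproliferative activity, read by MTT assay, with a stated time of 24 h; a higher number here means a weaker inhibitor, a lower number a stronger inhibitor. Compound 1 `COc1ccc(-c2cc(C(=O)/C=C/c3ccccc3)nc3cc(-c4ccccc4)nn23)cc1OC` gives 64100 nM in this assay, and compound 2 `COc1ccc(-c2cc(/C=C/C(=O)c3ccc(OC)c(OC)c3)nc3cc(-c4ccccc4)nn23)cc1` gives 48500 nM; the two numbers lie within the usual scatter of each other, so neither can be called the stronger inhibitor on this evidence. Compound 3 `COc1ccc(C(=O)/C=C/c2cc(-c3ccc(OC)c(OC)c3)n3nc(-c4ccccc4)cc3n2)cc1` has not yet been measured. It differs from compound 1 by 2-((4-methoxyphenyl)carbonyl)ethenyl in place of (2-phenylethenyl)carbonyl on an aromatic carbon, so the carbonyl and the double bond keep their place in the chain but exchange ends, and the outer ring gains a methoxy group. Within the data shown here, no measured pair shows what such an exchange does here, and both measured compounds sit at similarly weak levels, so the step from compound 1 to compound 3 is expected to stay within the scatter, a 1.2-fold lower number from compound 1 to compound 3 (0.07 log units; within the scatter). Compound 3 is therefore estimated at 55000 nM in this assay, within a range from 20000 nM to 150000 nM.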

Compound 3, half-maximal inhibitory concentration: 40000 nM
Compound 3: middle estimate off by 1.4-fold (0.14 log units), on the high side; measured number inside the range.
By their numbers in this assay, from the lowest: compounds 3, 2 and 1 (each within the scatter of the next).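

In this assay, putting 2-((4-methoxyphenyl)carbonyl)ethenyl in place of (2-phenylethenyl)carbonyl on this aromatic carbon gives a 1.6-fold lower number from compound 1 to compound 3 (0.20 log units; within the scatter). Among these compounds, this is the first measured step at this position, and it shows that exchanging the ends of the chain while adding a methoxy group to the outer ring leaves no readable difference in this assay. No measurement on hand offers an explanation for this result.

Because the exchange and the added methoxy group arrive together, the compounds shown cannot separate what each contributes, and the two could even offset each other. Also open, from the compounds shown here alone, is whether a quite different group at this position, such as an amine or a carboxylic acid in place of the whole chain, would move the number beyond the scatter.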